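Dihydroxy in place of dichloro: a step from a limit

The source may hold more compounds than are shown below. What is called first, only, known or untested is meant among the compounds shown, and "the series" means these compounds.

Compound 1 `COc1cccc(/C=C2\CCC/C(=C\c3cccc(OC)c3OC)C2=O)c1` gives 16400 nM
Compound 2 `COc1cccc(/C=C2\CCC/C(=C\c3cccc(O)c3)C2=O)c1OC` gives > 20000 nM (a limit)
Compound 3 `COc1cccc(/C=C2\CCC/C(=C\c3ccc(Cl)c(Cl)c3)C2=O)c1OC` gives > 20000 nM (a limit)

In a functional assay on A549 cells (Homo sapiens) for cytotoxicity, read by MTT assay, with a stated time of 72 h (a higher number here means a weaker inhibitor, a lower number a stronger inhibitor), compound 3 stands at a limit, > 20000 nM, and not at a number. That is the limit of > 20000 nM in this assay, at which 2 of the 3 values shown sit.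

Compound 4 `COc1cccc(/C=C2\CCC/C(=C\c3ccc(O)c(O)c3)C2=O)c1OC` differs from compound 3 at one place: 3,4-dihydroxyphenyl in place of 3,4-dichlorophenyl on a double-bonded chain carbon bound to a double-bonded ring carbon.

Among the compounds with values here, three measured steps bear on this change. The first is an at least 1.2-fold higher number from compound 1 to compound 3 (0.08 log units; that floor lies within the scatter), the second at least 1.2-fold higher number from compound 1 to compound 2 (0.08 log units; that floor lies within the scatter), and the third step that the two limits leave unreadable from compound 2 to compound 3. None shows a change beyond the scatter.

Only compound 1 gives a number, at 16400 nM, so a modest move to a lower number is expected. Compound 2 , with its 3-hydroxyphenyl, argues against a large gain.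

The expected step is an at least 1.3-fold lower number from compound 3 to compound 4 (0.12 log units; that floor lies within the scatter). For compound 4 the estimated value is 15000 nM, with an expected range of 6000 nM to 30000 nM.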

Compound 4, half-maximal inhibitory concentration: > 20000 nM
Compound 4 ended at the assay's limit; the forecaster's own chance of this, stated with the estimate: 40%; at least 1.3-fold (0.12 log units) between middle value and limit.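

With 3,4-dihydroxyphenyl in place of 3,4-dichlorophenyl, compound 4 still gives only a limit in this assay, so groups with different counts of hydrogen-bond donors end at the same reading: the limit of > 20000 nM in this assay, at which 3 of the 4 values shown sit. Within the data shown here, the steps linking compound 4 to the other compounds at the limit cannot be read, and the only readable step is an at least 1.2-fold higher number from compound 1 to compound 4 (0.08 log units; that floor lies within the scatter).

Going by these compounds, how compound 2, compound 3 and compound 4 rank among themselves stays open. Also open, on these data alone, is whether an amine or a carboxylic acid at this place would give a measurable number.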